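A few compounds are considered here, and "the series" means these few. Any claim that something is new, unique, unknown or untested is made for them only; others in the source may bear on it.

The measured compounds and their numbers:

Compound 1, `CC(C)c1n[nH]c2c(NCc3ccc(-c4ccccn4)cc3)nc(SCCn3ccnc3)nc12`, gives 155 nM in a functional assay on HT cells (Homo sapiens) for antiproliferative activity, read by fluorescence, with a stated time of 72 h; on this read-out higher numbers stand for weaker inhibition of growth and lower numbers for stronger inhibition of growth.
Compound 2, `COCSc1nc(NCc2ccc(-c3ccccn3)cc2)c2[nH]nc(C(C)C)c2n1`, gives 340 nM in this assay.
Compound 3, `CC(C)c1n[nH]c2c(NCc3ccc(-c4ccccn4)cc3)nc(SCCNC(N)=O)nc12`, gives 240 nM in this assay.

Compound 3 holds the second highest of the three numbers; its nearest neighbour is compound 2 and its furthest is compound 1, and both of those gaps fall within the scatter, so no order among them can be read with confidence. Among the measured compounds shown here, the only step beyond the scatter is a 2.2-fold higher number from compound 1 to compound 2 (0.34 log units; beyond the scatter), and it is modest.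

Compound 4, `CSCCSc1nc(NCc2ccc(-c3ccccn3)cc2)c2[nH]nc(C(C)C)c2n1`, has not yet been measured. It differs from compound 3 in one place: methylsulfanyl in place of ureido on a saturated chain carbon, two bonds along the chain from a sulfur. For the measured compounds named here, the steps that bear on this change are those that alter the same end of the chain. The step of a 1.5-fold higher number from compound 1 to compound 3 (0.19 log units; within the scatter) and the step of a 1.4-fold lower number from compound 2 to compound 3 (0.15 log units; within the scatter) each stayed within the scatter, and all three measured variants of this chain end sit within a narrow band. On that basis the swap to methylsulfanyl is expected to give at most a small step, a 1.0-fold higher number from compound 3 to compound 4 (0.02 log units; within the scatter), with no direction clearly favoured. Compound 4 is therefore estimated at 250 nM, with a likely range from 120 nM to 520 nM.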

Compound 4, concentration for 50% growth inhibition: 975 nM
The estimate for compound 4 lay 3.9-fold (0.59 log units) below the measured number; the measured number lies above the stated range.
By their numbers in this assay, from the lowest: compounds 1, 3 and 2 (each within the scatter of the next, the first and the last beyond it); then compound 4.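

Among the compounds shown here, the chain end on the sulfur is less indifferent than the three earlier compounds suggested: in this assay, methylsulfanyl in place of ureido gives a 4.1-fold higher number from compound 3 to compound 4 (0.61 log units; beyond the scatter), and methylsulfanyl in place of 1H-imidazol-1-yl gives a 6.3-fold higher number from compound 1 to compound 4 (0.80 log units; beyond the scatter), both larger than any step among the earlier compounds. The change from methoxy to (methylsulfanyl)methyl on the saturated chain carbon bound to a sulfur also goes the same way, with a 2.9-fold higher number from compound 2 to compound 4 (0.46 log units; beyond the scatter), so all three earlier chain ends give lower numbers than methylsulfanyl, and by steps beyond the scatter. Nothing available here accounts for this separation.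

The compounds shown leave open whether it is the sulfur of methylsulfanyl that sets compound 4 apart, since an end such as a plain ethyl or propyl group would be needed to compare with it. They also leave open whether an end carrying an amine or a carboxylic acid, or methylsulfanyl on a longer chain, would stand with compound 4 or with compounds 1, 2 and 3.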